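The source may hold more compounds than are shown below. What is called first, only, known or untested is meant among the compounds shown, and "the series" means these compounds.

Measured compounds:
- compound 1, `COc1cccc(-c2nn(-c3ccccc3)cc2-c2ccnc(NCCCNC(=O)Nc3ccc(Cl)c(Cl)c3)c2)c1`: 100000 nM
- compound 2, `O=C(NCCCNc1cc(-c2cn(-c3ccccc3)nc2-c2cccc(O)c2)ccn1)c1ccccc1`: 100000 nM

Both compounds were tested in a functional assay on PC-3 cells (Homo sapiens) for cytotoxicity; on this read-out lower numbers stand for higher toxicity in this test and higher numbers for lower toxicity in this test. In that test compound 1 gives 100000 nM. Compound 2 shares the core of compound 1 but carries a benzamide on its three-carbon chain and a hydroxyl on the phenyl attached to the core. In that test compound 2 gives 100000 nM. On the digits shown, compound 2 stands level with compound 1, and the two values lie within the scatter of each other, so no order between them can be read from these numbers.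

Compound 3, `O=C(NCCCNc1cc(-c2cn(-c3ccccc3)nc2-c2cccc(O)c2)ccn1)c1ccc(F)cc1`, has not yet been measured in this assay. It differs from compound 2 in one place: fluoro in place of hydrogen on an aromatic carbon, on an aromatic carbon of a six-membered aromatic ring of carbon only, so that the benzamido group of compound 2 becomes a ((4-fluorophenyl)carbonyl)amino group. Within the data shown here, no pair of measured compounds shows what such a change does here. Since compound 2 shows 100000 nM and compound 1 shows 100000 nM, nothing in the data points to a shift, and the step from compound 2 to compound 3 is expected to stay within the scatter, as no change at the digits printed from compound 2 to compound 3 (within the scatter). For compound 3 the expected value in this assay is therefore estimated at 100000 nM, with a range from 40000 nM to 200000 nM.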

Compound 3, concentration lethal to 50% of the cells: 44300 nM
For compound 3 the middle estimate is 2.3-fold (0.35 log units) above the measured one; the range from low to high includes it.
By their numbers in this assay, from the lowest: compound 3; then compounds 1 and 2 (each within the scatter of the next).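

In this assay, fluoro in place of hydrogen on an aromatic carbon, para to a large group, gives a 2.3-fold lower number from compound 2 to compound 3 (0.35 log units; beyond the scatter), so a single added fluorine on the phenyl of the benzamido group is enough to move the read-out towards higher toxicity in this test. Among these compounds, the earlier compounds offered no pair differing in one place, which makes this the first change here that can be read on its own, and it shows that this carbon of the benzamido group's phenyl is not silent, although the step is modest and rests on one pair of compounds. Nothing in the material shown explains why phenyl to 4-fluorophenyl lowers the number.

On these data alone, it remains open whether chloro, methoxy, an amine or a carboxylic acid at the same carbon would move the number further, leave it unchanged or reverse the step, and whether fluoro on another carbon of that phenyl would do the same. Also open, as far as these compounds go, is whether the step from phenyl to 4-fluorophenyl would hold with a longer chain in place of the three-carbon chain, or with methoxy in place of the hydroxyl on the phenyl attached to the core.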